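From Naphthalen-1-yl to Pyridin-3-yl: Expected Cytotoxicity

The source may report more compounds than this note shows. Statements on the series, on what has been measured and on what is new or still open speak of the compounds shown alone.

Compound 2 `Cc1cc(C#N)cc(C)c1Oc1nc(Nc2ccc(C#N)cc2)ncc1-c1cccc2ccccc12` carries a naphthalen-1-yl group on the shared core. In an ADME assay on MT4 cells (Homo sapiens) for cytotoxicity, read by MTT assay, with a stated time of 5 days (on this read-out higher numbers stand for lower toxicity in this test and lower numbers for higher toxicity in this test), compound 2 gives only a limit, > 267000 nM (the limit of > 267000 nM in this assay, at which 1 of the 2 values shown sits). Among the measured compounds shown here, compound 1 `Cc1cc(C#N)cc(C)c1Oc1nc(Nc2ccc(C#N)cc2)ncc1-c1cccs1`, bearing thiophen-2-yl at the same place, gives 6430 nM in this assay, and the one measured step is an at least 41-fold higher number from compound 1 to compound 2 (1.61 log units; beyond the scatter). Compound 3 `Cc1cc(C#N)cc(C)c1Oc1nc(Nc2ccc(C#N)cc2)ncc1-c1cccnc1` differs from compound 2 by pyridin-3-yl in place of naphthalen-1-yl on an aromatic carbon. With one six-membered aromatic ring entering where two left, the step is estimated as an at least 17-fold lower number from compound 2 to compound 3 (1.25 log units; beyond the scatter), a move back toward compound 1. Compound 3 is therefore expected near 15000 nM, within 4000 nM to 100000 nM.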

Compound 3, half-maximal cytotoxic concentration: 13500 nM
For compound 3 the middle estimate is 1.1-fold (0.05 log units) above the measured one; measured number inside the range.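

In this assay, the step of an at least 19-fold lower number from compound 2 to compound 3 (1.29 log units; beyond the scatter) shows that a single pyridin-3-yl ring does not keep the high reading seen with naphthalen-1-yl, while a 2.1-fold higher number from compound 1 to compound 3 (0.32 log units; beyond the scatter) separates it only modestly from thiophen-2-yl. Both groups with one aromatic ring therefore read far lower than naphthalen-1-yl at this position. The true size of the drop remains unknown, since compound 2 gives a limit and not a number: the limit of > 267000 nM in this assay, at which 1 of the 3 values shown sits.

The compounds shown leave open whether the count of rings or the ring nitrogen matters more here. A plain phenyl ring or a morpholine would help to separate these readings.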